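Swapping the aminophenyl for a fluorophenylamino group

The compounds below may be only part of what the source reports. "The series", "measured", "known", "first", "only" and "open" are said of these compounds alone.

Measured compounds:
compound 1 `CC(C)Cc1ccc(C(C)c2nnc3sc(-c4ccc(N)cc4)nn23)cc1`: 78.8%
compound 2 `CCCCNc1nn2c(C(C)c3ccc(CC(C)C)cc3)nnc2s1`: 80.3%

In a functional assay on the whole organism (strain Wistar albino) for inhibition, with Rattus norvegicus as the target, read by paw edema, with a stated time of 4 h, at a dose of 70 mg/kg by the oral route (on this read-out lower numbers stand for less inhibition and higher numbers for more inhibition at the one dose given (going by the name of the read-out)), compound 1 gives 78.8% and compound 2 gives 80.3%. Compound 1 holds the lower of the two numbers, but the step of a number 1.5 percentage points higher from compound 1 to compound 2 (within the scatter) stays within the scatter. Compound 3 `CC(C)Cc1ccc(C(C)c2nnc3sc(Nc4ccc(F)cc4)nn23)cc1` differs from compound 1 by (4-fluorophenyl)amino in place of 4-aminophenyl on an aromatic carbon. Among the measured compounds shown here, the only measured step that bears on this, a number 1.5 percentage points higher from compound 1 to compound 2 (within the scatter), also swaps the group on that aromatic carbon and barely moved the read-out. No step beyond the scatter is therefore expected here. Compound 3 is estimated at 79%, with a range from 68% to 88%, an expected step of a number 0.2 percentage points higher from compound 1 to compound 3 (within the scatter).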

Compound 3, a percentage reported as inhibition, in the whole organism at one dose (the size of the read-out at that dose, not a potency): 28%
Beside the measured number, compound 3's estimate is 51 percentage points above it, and the stated range ends above it.
By their numbers in this assay, from the lowest: compound 3; then compounds 1 and 2 (each within the scatter of the next).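

In this assay this aromatic carbon turns out not to accept every group, with a number 50.8 percentage points lower from compound 1 to compound 3 (beyond the scatter) and a number 52.3 percentage points lower from compound 2 to compound 3 (beyond the scatter) even though 4-aminophenyl and butylamino gave values within the scatter of each other. Of the three groups, (4-fluorophenyl)amino is the only one that stands apart from the others. Nothing available explains the drop. Still open, on these data alone, is whether the loss follows the fluorine or the amino-linked phenyl ring. Phenylamino without the fluorine, or 4-fluorophenyl joined directly to the carbon, would separate the two.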